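A few compounds are considered here, and "the series" means these few. Any claim that something is new, unique, unknown or untested is made for them only; others in the source may bear on it.

Compound 1 `CN(C)C(=O)c1cccnc1NCCCN1CCN(c2ccccc2C#N)CC1`, compound 2 `CCOc1ccccc1N1CCN(CCCNc2ncccc2C(=O)N(C)C)CC1` and compound 3 `CN(C)C(=O)c1cccnc1NCCCN1CCN(c2ccccc2OCC(F)(F)F)CC1` share one core and differ only in a single group on an aromatic carbon. In a functional assay on aorta for antagonist activity at Alpha-1D adrenergic receptor (Rattus norvegicus) (a higher number here means weaker binding, a lower number tighter binding), compound 1 gives 10 nM, compound 2 gives 7.94 nM and compound 3 gives 15.9 nM. Compound 3 thus carries the highest of the three numbers, but the gaps to the other two are small: the step of a 1.6-fold higher number from compound 1 to compound 3 (0.20 log units; within the scatter) and the step of a 2.0-fold higher number from compound 2 to compound 3 (0.30 log units; within the scatter) both stay within the scatter, and so does the step of a 1.3-fold lower number from compound 1 to compound 2 (0.10 log units; within the scatter). Compound 4 `CN(C)C(=O)c1cccnc1NCCCN1CCN(c2ccccc2OCC2CC2)CC1` has not yet been measured in this assay. Its change from compound 3 is cyclopropyl in place of trifluoromethyl on a saturated chain carbon bound to an oxygen on an aromatic ring. Among the compounds with values here, the one measured step at the same place is the step of a 2.0-fold higher number from compound 2 to compound 3 (0.30 log units; within the scatter), which exchanged methyl for trifluoromethyl there and stayed within the scatter; the two steps that swapped the whole group on the aromatic carbon were just as small. With the same place touched once more, the expected step of a 1.3-fold lower number from compound 3 to compound 4 (0.12 log units; within the scatter) is no larger than the scatter, in no particular direction. Compound 4 is therefore estimated at 12 nM, with a range from 5 nM to 30 nM.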

Compound 4, dissociation constant: 10 nM
Compound 4: middle estimate off by 1.2-fold (0.08 log units), on the high side, and the stated range covers the measured number.
By their numbers in this assay, from the lowest: compounds 2, 1, 4 and 3 (each within the scatter of the next).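

In this assay, a ring can stand at the end of the group on the oxygen without a readable shift: the step of a 1.6-fold lower number from compound 3 to compound 4 (0.20 log units; within the scatter) and the step of a 1.3-fold higher number from compound 2 to compound 4 (0.10 log units; within the scatter) both stay small, so cyclopropyl joins methyl and trifluoromethyl as groups that this place accepts among the four compounds. Until now only open groups had been seen on this saturated chain carbon bound to an oxygen on an aromatic ring, and compound 4 adds a three-membered ring of carbon only, which still does not move the number beyond the scatter, just as the wider swap of cyclopropylmethoxy for cyano gives no change at the digits printed from compound 1 to compound 4 (within the scatter) and so adds no readable difference. No measurement available here explains why these groups read alike.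

Still open, from the compounds shown here alone, is whether this tolerance would survive a group of a different kind at the same place, such as an amine or a carboxylic acid, or a bulkier one such as cyclohexyl or a longer chain. Going by these compounds, whether any of these groups would pull apart at another adrenergic receptor also remains unknown.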